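Working notes: ring-amine substituent, compound 2 to compound 4

The source may hold more compounds than are shown below. What is called first, only, known or untested is meant among the compounds shown, and "the series" means these compounds.

Measured so far:
compound 1 `Cc1cccc2sc(NC(=O)CCN3CCN(CCN(C)C)CC3)nc12`: 2150 nM
compound 2 `CCCCCCN1CCN(CCC(=O)Nc2nc3c(C)cccc3s2)CC1`: no result reported
compound 3 `Cc1cccc2sc(NC(=O)CCN3CCN(CC4CCCCC4)CC3)nc12`: no result reported

In an assay on HEK293 cells for antagonist activity at P2X purinoceptor 7 (Homo sapiens), read by fluorescence, with stated times of 30 min and 120 min (on this read-out higher numbers stand for weaker inhibition and lower numbers for stronger inhibition), compound 1 gives 2150 nM. In this assay compound 2 has no result reported, and compound 3 has no result reported, so compound 1 is the only anchor in the set. Compound 4 `Cc1cccc2sc(NC(=O)CCN3CCN(c4ccccn4)CC3)nc12` is to be measured in this assay. It differs from compound 2 by pyridin-2-yl in place of hexyl on an amine nitrogen in a ring. Going by the values given here, no measured pair shows what this exchange does, so neither size nor direction of the step from compound 2 to compound 4 can be read from the data; a modest shift either way, or none beyond the scatter, is equally plausible. Taking compound 1 at 2150 nM as the sole reference, compound 4 is expected near 3000 nM, within a range of 800 nM to 12000 nM.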

Compound 4, half-maximal inhibitory concentration: 1400 nM
Compound 4: the middle estimate sits 2.1-fold (0.33 log units) above what was measured; low and high end bracket the measured number.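

In this assay, pyridin-2-yl in place of 2-(dimethylamino)ethyl on an amine nitrogen in a ring gives a 1.5-fold lower number from compound 1 to compound 4 (0.19 log units; within the scatter). Going by these compounds alone, this is the first readable comparison at this position, and for this one pair the aromatic ring and the amine-bearing chain do not separate beyond the scatter. Nothing available explains this result. Steps involving compound 2 or compound 3 cannot be read, as neither has a single value. Going by these compounds, how a carboxylic acid or a phenyl on this nitrogen would read remains open.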